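The compounds below may be only part of what the source reports. "The series", "measured", "known", "first", "only" and "open" are said of these compounds alone.

In a functional assay on DU-145 cells (Homo sapiens) for cytotoxicity, read by MTT assay, with a stated time of 72 h (a higher number here means that more compound is needed for the effect, a lower number that less compound is needed), the measured compounds are:
compound 1 `CCc1cccc2c(O)c(-c3occ(C)c3C(=O)O)ccc12` with 8.7 ug/mL
compound 2 `CCc1cccc2c(OC)c(-c3occ(C)c3C(=S)OC)ccc12` with 5.7 ug/mL
compound 3 `CCOc1c(-c2occ(C)c2C(=O)OC)ccc2c(CC)cccc12` with 1.9 ug/mL

Compound 2 at 5.7 ug/mL sits within the scatter of compound 1 and above compound 3 by a gap beyond the scatter. The change to compound 4 `CCc1cccc2c(OC)c(-c3occ(C)c3COCC(F)(F)F)ccc12` is a group of 7 heavy atoms (3 carbon, 1 oxygen, 3 fluorine; no ring) in place of a group of 4 heavy atoms (2 carbon, 1 oxygen, 1 sulfur; no ring), on an aromatic carbon and the entering group is (2,2,2-trifluoroethoxy)methyl, on an aromatic carbon of a five-membered aromatic ring with 1 oxygen. Going by the values given here, no two measured compounds differ in only one place, so the series offers no direct precedent for this change. Among the compounds with values here, the only guide is the spread of the three values, with compound 3 at 1.9 ug/mL and compound 1 at 8.7 ug/mL as its ends. No step beyond the scatter is expected in this assay for this change, although the basis for that expectation is thin. The estimated step is a 1.1-fold lower number from compound 2 to compound 4 (0.06 log units; within the scatter) and it would lie within the scatter. For compound 4 the expected value is 5 ug/mL with an estimated range from 1.8 ug/mL to 14 ug/mL in the same read-out.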

Compound 4, concentration for half-maximal effect: 5.7 ug/mL
The estimate for compound 4 lay 1.1-fold (0.06 log units) below the measured number, within the range that was stated.
By their numbers in this assay, from the lowest: compound 3; then compounds 2, 4 and 1 (each within the scatter of the next).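

In this assay, going by these compounds alone, (2,2,2-trifluoroethoxy)methyl on the aromatic carbon of the five-membered aromatic ring with 1 oxygen gives no change at the digits printed from compound 2 to compound 4 (within the scatter), the first step between compounds that differ in one place. This position, next to the ring atom that bears a methyl group, therefore takes a ring-free group of 7 heavy atoms in place of one of 4 heavy atoms without a reading beyond the scatter. No measurement shown accounts for this result, so no cause can be assigned to it.

From the compounds shown here alone, whether an amine or an amide on this carbon would also stay within the scatter remains open. Within the data shown here, no one-place step reaches compound 3 either, so its value of 1.9 ug/mL cannot be tied to any single change.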